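Notes on a hydroxy to methoxy change

The source may report more compounds than this note shows. Statements on the series, on what has been measured and on what is new or still open speak of the compounds shown alone.

In a functional assay on SKBR cells (Homo sapiens) for cytotoxicity, read by resazurin assay, with a stated time of 72 h (on this read-out higher numbers stand for weaker inhibition and lower numbers for stronger inhibition), compound 1 (`COc1cc(/C=C/C(=O)OCCCCCCO[N+](=O)[O-])ccc1O`) gives 15200 nM, compound 2 (`O=C(/C=C/c1ccc(OCCCCO[N+](=O)[O-])c(O)c1)OCCCCO[N+](=O)[O-]`) gives 3230 nM, and compound 3 (`O=C(/C=C/c1ccc(OCCCCCCO[N+](=O)[O-])c(O)c1)OCCCCCCO[N+](=O)[O-]`) gives 39700 nM. Compound 3 holds the highest of the three numbers, so it is the weakest here, with its gaps to both others beyond the scatter. Compound 4 (`COc1cc(/C=C/C(=O)OCCCCCCO[N+](=O)[O-])ccc1OCCCCCCO[N+](=O)[O-]`) differs from compound 3 by methyl in place of hydrogen on an oxygen on an aromatic ring. Among the measured compounds shown here, no measured pair isolates this change, and the three values give no size for it. In this assay, no step beyond the scatter is expected, with compound 3 at 39700 nM as the anchor. The expected change is a 1.1-fold lower number from compound 3 to compound 4 (0.05 log units; within the scatter). The estimate for compound 4 is 35000 nM, with an expected range from 12000 nM to 90000 nM.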

Compound 4, half-maximal inhibitory concentration: > 50000 nM
Compound 4: only a limit was reported (the forecaster's own chance of this, stated with the estimate: 15%); at least 1.4-fold (0.15 log units) between middle value and limit.
By their numbers in this assay, from the lowest: compound 2; then compound 1; then compound 3. At a limit, above all of these: compound 4.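

In this assay compound 4 gives > 50000 nM as a limit and not a number. The step of an at least 1.2-fold higher number from compound 3 to compound 4 (0.10 log units; that floor lies within the scatter) leaves methyl in place of hydrogen on this oxygen without a resolved size. With the hydroxy of compound 1 as the starting point, 6-(nitrooxy)hexyl in place of hydrogen on this oxygen weakens inhibition, with an at least 3.2-fold higher number from compound 1 to compound 4 (0.51 log units; beyond the scatter) as the step.

As far as these compounds go, how far compound 4 lies past its limit remains unknown. From the compounds shown here alone, whether a longer chain or a chain carrying an amine on this oxygen would read differently also stays open.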